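Replacing the hexyl group of compound 3

This account rests on a few compounds, and the source may have more. Where it says the series, first, only, none or still open, it means among the compounds named here.

- compound 1 `C=C/C=C\[C@H](C)[C@H](OC(N)=O)[C@@H](C)[C@H](O)CC/C=C\C(C)[C@@H](O)[C@@H](C)/C=C\CC[C@@H]1O[C@@H](OC)[C@H](C)[C@@H](OCOC)[C@@H]1C`: 15 nM
- compound 2 `COCO[C@H]1[C@@H](C)[C@H](CC/C=C\[C@H](C)[C@H](O)[C@@H](C)/C=C\CC[C@@H](O)[C@H](C)COC(N)=O)OC(=O)[C@@H]1C`: > 50 nM (a limit, not a number)
- compound 3 `CCCCCC[C@H](OC(N)=O)[C@@H](C)[C@H](O)CC/C=C\C(C)[C@@H](O)[C@@H](C)/C=C\CC[C@@H]1O[C@@H](OC)[C@H](C)[C@@H](OCOC)[C@@H]1C`: > 50 nM (a limit, not a number)

In a functional assay on PC-3 cells (Homo sapiens) for inhibition (on this read-out higher numbers stand for weaker inhibition of growth and lower numbers for stronger inhibition of growth), compound 3 gives > 50 nM, which is a limit and not a number. Its position is therefore known only as the limit of > 50 nM in this assay, at which 2 of the 3 values shown sit.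

The change to compound 4 `CCCCCC(C)(C)[C@H](OC(N)=O)[C@@H](C)[C@H](O)CC/C=C\C(C)[C@@H](O)[C@@H](C)/C=C\CC[C@@H]1O[C@@H](OC)[C@H](C)[C@@H](OCOC)[C@@H]1C` is a group of 8 heavy atoms (8 carbon; no ring) in place of a group of 6 heavy atoms (6 carbon; no ring), on a saturated chain carbon bound to an oxygen next to a carbonyl group and a saturated chain carbon. Hexyl leaves, and the group that enters likewise holds only carbon and no ring.

Going by the values given here, only one measured step touches this place: an at least 3.3-fold higher number from compound 1 to compound 3 (0.52 log units; beyond the scatter). Among the compounds with values here, that step shows what happens when hexyl enters, but no measured step starts from compound 3, and none shows what the new group does. With that single step as the guide, no step beyond the scatter is expected in this assay, in either direction, though a partial move back toward compound 1 at 15 nM cannot be excluded. The expected step is a step that the limit leaves unreadable from compound 3 to compound 4, and this remains an estimate resting on very little. For compound 4 the estimated value is 70 nM, with an expected range from 25 nM to 250 nM.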

Compound 4, concentration for 50% growth inhibition: 38 nM
The estimate for compound 4 lay 1.8-fold (0.27 log units) above the measured number; the measured number falls inside the stated range.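

In this assay, going by these compounds alone, compound 4 gives 38 nM, the first number at this place for a group that holds only carbon and no ring. Compound 3, with hexyl, had offered only a limit. The comparison with hexyl still has only a floor, an at least 1.3-fold lower number from compound 3 to compound 4 (0.11 log units; that floor lies within the scatter), so the group of 8 heavy atoms cannot be said to differ from hexyl in this assay. Within the data shown here, the comparison with 1-methylpenta-2,4-dien-1-yl is the first at this place with a measured size rather than a floor, a 2.5-fold higher number from compound 1 to compound 4 (0.40 log units; beyond the scatter), so this carbon-only group without a ring stays modestly behind the group of compound 1, and the change at this place does not recover the full value of compound 1.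

From the compounds shown here alone, the value of compound 3 remains a limit and not a number, so the true size of the step from hexyl stays unknown: the limit of > 50 nM in this assay, at which 2 of the 4 values shown sit. Also open is whether an amine, a carboxylic acid or a longer chain at this place would reach the value of compound 1 or move further from it.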